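Hydroxybenzoate esters of a retinoid alcohol: compound 4

The source may report more compounds than this note shows. Statements on the series, on what has been measured and on what is new or still open speak of the compounds shown alone.

Three esters of the shared core have been tested in an assay on B16-F10 cells for inhibition of Tyrosinase (Mus musculus), tested at 5 uM; on this read-out higher numbers stand for more inhibition at the one concentration tested (going by the name of the read-out) and lower numbers for less inhibition. Compound 1 `CC(/C=C/C1=CCCCC1(C)C)=C\C=C\C(C)=C\COC(=O)c1cc(O)ccc1O` gives 31.3%. Compound 2 `CC(/C=C/C1=CCCCC1(C)C)=C\C=C\C(C)=C\COC(=O)c1c(O)cccc1O` gives 45.4%. Compound 3 `COc1cc(O)c(C(=O)OC/C=C(C)/C=C/C=C(C)/C=C/C2=CCCCC2(C)C)c(O)c1` gives 41.9%, the second highest of the three numbers; it sits within the scatter of compound 2 and above compound 1, with the step of a number 10.6 percentage points higher from compound 1 to compound 3 (beyond the scatter) lying beyond the scatter. The change a number 3.5 percentage points lower from compound 2 to compound 3 (within the scatter) stays within the scatter.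

Compound 4 `CC(/C=C/C1=CCCCC1(C)C)=C\C=C\C(C)=C\COC(=O)c1cccc(O)c1O` differs from compound 3 in one place: a group of 8 heavy atoms (6 carbon, 2 oxygen; one six-membered aromatic ring of carbon only) in place of a group of 10 heavy atoms (7 carbon, 3 oxygen; one six-membered aromatic ring of carbon only), on a carbonyl carbon. For the measured compounds named here, the only steps that bear on this are those that move hydroxyls around the same ring or add a methoxy to it: a number 14.1 percentage points higher from compound 1 to compound 2 (beyond the scatter) and a number 10.6 percentage points higher from compound 1 to compound 3 (beyond the scatter) are modest, a number 3.5 percentage points lower from compound 2 to compound 3 (within the scatter) is within the scatter. All three aryl groups so far give numbers in a narrow band, and a 2,3-dihydroxyphenyl is expected to fall in that same band. Compound 4 is therefore expected near the middle of the measured range, with the step of a number 3.9 percentage points lower from compound 3 to compound 4 (within the scatter) estimated to be within the scatter in either direction. The estimate for compound 4 in this assay is 38%, in the range 25% to 50%.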

Compound 4, a percentage reported as inhibition, at one concentration (the size of the read-out at that concentration, not a potency): 36.7%
Beside the measured number, compound 4's estimate is 1.3 percentage points above it; measured number inside the range.
By their numbers in this assay, from the lowest: compounds 1, 4, 3 and 2 (each within the scatter of the next, the first and the last beyond it).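

Notes on the aryl group on the carbonyl carbon of the ester, read in this assay: the 2,3-dihydroxyphenyl of compound 4 lies within the scatter of each earlier aryl group (a number 5.2 percentage points lower from compound 3 to compound 4 (within the scatter); a number 8.7 percentage points lower from compound 2 to compound 4 (within the scatter); a number 5.4 percentage points higher from compound 1 to compound 4 (within the scatter)). Compound 4 therefore forms a bridge across the earlier gap beyond the scatter (a number 14.1 percentage points higher from compound 1 to compound 2 (beyond the scatter)), so the new dihydroxyphenyl pattern cannot be assigned to either end of the series. No measured information accounts for these numbers.

Going by these compounds, it remains open whether an amine or a carboxylic acid on this aromatic ring, or a ring with a single hydroxyl, would leave this narrow band. A single tested concentration also leaves the potency of these esters undefined.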